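Dropping the Bromine from a Benzofuran Amine Oxidase Inhibitor

The source may report more compounds than this note shows. Statements on the series, on what has been measured and on what is new or still open speak of the compounds shown alone.

Three compounds sharing a benzofuran core were measured in an assay on cells for inhibition of Amine oxidase [flavin-containing] B (Homo sapiens), read by fluorescence and Amplex Red, with a stated time of 15 min; a lower number here means a stronger inhibitor, a higher number a weaker inhibitor. Compound 1 `Cc1ccc2oc(-c3cccc(Br)c3)cc2c1` gives 250 nM, the lowest number of the three. Compound 3 `Cc1cccc2cc(-c3cccc(Br)c3)oc12` gives 3980 nM and compound 2 `Cc1cccc2cc(-c3ccccc3Br)oc12` gives 9680 nM; both lie beyond the scatter above compound 1, so compound 1 is the strongest inhibitor in this set. Compound 4 `Cc1ccc2oc(-c3ccccc3)cc2c1` has not yet been measured. It differs from compound 1 by hydrogen in place of bromo on an aromatic carbon. Going by the values given here, no measured pair shows this change, so the step is a judgment: the expected step of a 4.8-fold higher number from compound 1 to compound 4 (0.68 log units; beyond the scatter) is toward a weaker inhibitor, beyond the scatter. Compound 4 is therefore expected to give about 1200 nM in this assay, within a range of 350 nM to 4500 nM.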

Compound 4, half-maximal inhibitory concentration: 880 nM
Estimate against measurement, compound 4: 1.4-fold (0.13 log units) above; the range from low to high includes it.
By their numbers in this assay, from the lowest: compound 1; then compound 4; then compound 3; then compound 2.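

Removing the bromo from this aromatic carbon, meta to a large group, gives a 3.5-fold higher number from compound 1 to compound 4 (0.55 log units; beyond the scatter) in this assay, the first direct measure of what this one atom contributes. The step is modest, and compound 4, which carries hydrogen there, still gives 880 nM, so the bromo adds strength here but is not required for inhibition. Nothing available explains the size of this step. The compounds shown leave open how a chlorine, a methoxy group or an amine would compare at this carbon. They also leave open whether bromo has the same effect on other cores.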